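Swapping the methoxyphenyl for a trifluoromethylphenyl group

The compounds below may be only part of what the source reports. "The series", "measured", "known", "first", "only" and "open" are said of these compounds alone.

Of the compounds shown here, three sharing one core have been tested in an assay on isolated protein for inhibition of aldehyde dehydrogenase 1A1 (Homo sapiens), read by spectrophotometry, tested at 10 uM; a higher number here means more inhibition at the concentration tested (going by the name of the read-out), a lower number less inhibition. Compound 1 `Cc1ccc(Cn2c(CN3CCN(C(=O)C4CC4)CC3)nc3ccccc32)cc1` gives 51.5%. Compound 2 `O=C(C1CC1)N1CCN(Cc2nc3ccccc3n2Cc2ccc(Cl)cc2)CC1` gives 56.6%. Compound 3 `COc1cccc(Cn2c(CN3CCN(C(=O)C4CC4)CC3)nc3ccccc32)c1` gives 44.4%, the lowest of the three numbers: its gap to compound 1 is within the scatter, while the step of a number 12.2 percentage points lower from compound 2 to compound 3 (beyond the scatter) is beyond it.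

Compound 4 `O=C(C1CC1)N1CCN(Cc2nc3ccccc3n2Cc2ccc(C(F)(F)F)cc2)CC1` differs from compound 3 in one place: 4-(trifluoromethyl)phenyl in place of 3-methoxyphenyl on a saturated chain carbon bound to an aromatic nitrogen. The two steps that bear on this change both lead into compound 3 from a compound carrying a 4-substituted phenyl: a number 7.1 percentage points lower from compound 1 to compound 3 (within the scatter) and a number 12.2 percentage points lower from compound 2 to compound 3 (beyond the scatter). For the measured compounds named here, the change to compound 4 runs the other way, from the 3-methoxyphenyl back to a phenyl substituted in the 4-position, now with a trifluoromethyl group that none of the measured compounds carries. A modest rise in this assay is therefore expected, in the direction of compounds 1 and 2, with a size not far from those two steps.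

For compound 4 the estimated value in this assay is 53%, with a range from 40% to 66%, which is expected to mean the step of a number 8.6 percentage points higher from compound 3 to compound 4 (within the scatter).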

Compound 4, a percentage reported as inhibition, at one concentration (the size of the read-out at that concentration, not a potency): 37%
Beside the measured number, compound 4's estimate is 16 percentage points above it; the measured number lies below the stated range.
By their numbers in this assay, from the lowest: compounds 4, 3, 1 and 2 (each within the scatter of the next, the first and the last beyond it).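

Within this assay the identity of the group on the phenyl ring matters more than the earlier compounds could show: the swaps on the same aromatic carbon are trifluoromethyl for methyl (a number 14.5 percentage points lower from compound 1 to compound 4 (beyond the scatter)) and trifluoromethyl for chloro (a number 19.6 percentage points lower from compound 2 to compound 4 (beyond the scatter)). Having a group on that carbon is therefore not enough by itself, since the change from the 3-methoxyphenyl to the 4-(trifluoromethyl)phenyl group (a number 7.4 percentage points lower from compound 3 to compound 4 (within the scatter)) gives no separation beyond the scatter, so the clear margin of compound 2 over compound 3 cannot be credited to the substitution place alone. Nothing measured here explains why trifluoromethyl differs from methyl and chloro in this series.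

Going by these compounds, it remains open how an unsubstituted phenyl, a fluoro group, a nitrile or a carboxylic acid would behave at this place on the saturated chain carbon bound to an aromatic nitrogen. Each number is also a reading at a single concentration, so the compounds shown leave open how they would rank in a full potency measurement.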